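Quinoline tetrazoles: ethyl for trifluoromethyl on the carbocyclic ring

A few compounds are considered here, and "the series" means these few. Any claim that something is new, unique, unknown or untested is made for them only; others in the source may bear on it.

Compound 1 `CCc1cccc2cc(C(=O)O)cnc12`: > 50 mg/kg
Compound 2 `FC(F)(F)c1cccc2cc(-c3nn[nH]n3)cnc12`: < 25 mg/kg

In a functional assay on the whole organism (strain Sprague-Dawley) for inhibition, with Rattus norvegicus as the target (on this read-out higher numbers stand for an effect only at larger amounts of compound and lower numbers for an effect already at smaller amounts), compound 2 sits at the limit of < 25 mg/kg in this assay, at which 1 of the 2 values shown sits, which is a limit of the assay and not a number. Compound 1 sits at the limit of > 50 mg/kg in this assay, at which 1 of the 2 values shown sits, also a limit. For the measured compounds named here, the two compounds differ in more than one place, so no measured step links them. Compound 3 `CCc1cccc2cc(-c3nn[nH]n3)cnc12` carries ethyl in place of trifluoromethyl on an aromatic carbon. The step from compound 2 to compound 3 in this assay is expected to be small, toward larger amounts if anything, as a number no lower from compound 2 to compound 3 (the limit leaves the size open). Compound 3 is expected at 25 mg/kg, within 10 mg/kg to 60 mg/kg.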

Compound 3, minimum effective dose: 2.5 mg/kg
Compound 3: middle estimate off by 10-fold (1.00 log units), on the high side, and the stated range ends above it.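

In this assay, with ethyl held on the core, 2H-tetrazol-5-yl in place of carboxy on an aromatic carbon gives an at least 20-fold lower number from compound 1 to compound 3 (1.30 log units; beyond the scatter). Compound 2 remains a limit of the assay: the limit of < 25 mg/kg in this assay, at which 1 of the 3 values shown sits.
The step for ethyl in place of trifluoromethyl cannot be read, so the effect of that change stays unsized even though compound 3 gives a number, 2.5 mg/kg.

Open, as far as these compounds go, is how a propyl chain, a methoxy group or an amine would read at this place on the ring. Also open, from the compounds shown here alone, is whether the tetrazole step holds with any group other than ethyl there.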